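The source may report more compounds than this note shows. Statements on the series, on what has been measured and on what is new or still open speak of the compounds shown alone.

Compound 1, `CCOC(=O)c1c(-c2cc(F)cc(OC)c2)[nH]c2cc(OC)ccc2c1=O`, in an ADME assay on HepG2 cells (Homo sapiens) for cytotoxicity, read by luminescence, with a stated time of 72 h; a higher number here means that more compound is needed for the effect, a lower number that less compound is needed: compound 1 gives > 21500 nM, a limit of the assay.
Compound 2, `CCOC(=O)c1c(-c2cccc(-c3ccccc3)c2)[nH]c2cc(OC)ccc2c1=O`: compound 2 gives > 21500 nM, a limit of the assay.
Compound 3, `CCOC(=O)c1c(-c2cccc(S(C)(=O)=O)c2)[nH]c2cc(OC)ccc2c1=O`: compound 3 gives > 21500 nM, a limit of the assay.

Compound 2 thus stands only at a limit, and so do the other two values shown; all three sit at the limit of > 21500 nM in this assay, at which 3 of the 3 values shown sit. Compound 4, `CCOC(=O)c1c(-c2cccc([N+](=O)[O-])c2)[nH]c2cc(OC)ccc2c1=O`, differs from compound 2 by nitro in place of phenyl on an aromatic carbon. Going by the values given here, the one measured step that bears on a change at this position is a step that the two limits leave unreadable from compound 2 to compound 3, whose size the two limits leave unreadable, so it gives no hint of direction. With nothing pointing beyond the scatter, compound 4 is expected to sit at a limit as well, with an estimated value of 21500 nM between 10000 nM and 50000 nM. The expected step of a number no higher from compound 2 to compound 4 (the limit leaves the size open) is therefore none beyond the scatter.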

Compound 4, half-maximal effective concentration: > 21500 nM
Compound 4 ended at the assay's limit; the forecaster's own chance of this, stated with the estimate: 85%; the middle value sits exactly at the limit.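

No step can be read among compound 1, compound 2, compound 3 and compound 4, because all of them sit at the same limit: the limit of > 21500 nM in this assay, at which 4 of the 4 values shown sit.

The compounds shown leave open how much of each is needed for the effect in this assay, and whether swapping these groups changes that amount at all.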